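The compounds below may be only part of what the source reports. "The series", "measured", "known", "first", "only" and "open" are said of these compounds alone.

Compounds measured so far:
- Compound 1 `CN(C)CCn1cnnc1-c1cc(Oc2ccc(NC(=O)N/N=C/c3c[nH]c4ccccc34)cc2F)ccn1`: in a functional assay on U-87MG ATCC cells (Homo sapiens) for cytotoxicity, read by MTT assay, with a stated time of 72 h (a lower number here means a stronger inhibitor, a higher number a weaker inhibitor), compound 1 gives 690 nM
- Compound 2 `COc1ccc(/C=N/NC(=O)Nc2ccc(Oc3ccnc(-c4nncn4CCN(C)C)c3)c(F)c2)c(OC)c1`: in this assay compound 2 gives 12600 nM
- Compound 3 `CN(C)CCn1cnnc1-c1cc(Oc2ccc(NC(=O)N/N=C/c3ccc(F)cc3Cl)cc2F)ccn1`: in this assay compound 3 gives 1210 nM

Among these three numbers compound 3 stands second highest. Its nearest neighbour is compound 1, with a 1.8-fold higher number from compound 1 to compound 3 (0.24 log units; within the scatter), a gap within the scatter; its furthest is compound 2, with a 10-fold lower number from compound 2 to compound 3 (1.02 log units; beyond the scatter), a large step. The change from compound 3 to compound 4 `CN(C)CCn1cnnc1-c1cc(Oc2ccc(NC(=O)N/N=C/c3ccc(O)cc3O)cc2F)ccn1` is 2,4-dihydroxyphenyl in place of 2-chloro-4-fluorophenyl on a carbon with a double bond to nitrogen. Going by the values given here, only the steps that replace the group on this same carbon bear on it. The step of an 18-fold higher number from compound 1 to compound 2 (1.26 log units; beyond the scatter) and the step of a 10-fold lower number from compound 2 to compound 3 (1.02 log units; beyond the scatter) both show that a 2,4-disubstituted phenyl carrying two oxygen substituents sits far weaker than either the indolyl or the chloro-fluoro phenyl. Among the compounds with values here, compound 4 carries oxygen at the same two positions, though as hydroxyls rather than methoxy groups, so the series gives no direct precedent for this exact group. On that basis compound 4 is expected to show a higher number than compound 3 in this assay, with a 3.7-fold higher number from compound 3 to compound 4 (0.57 log units; beyond the scatter) as the expected step, though smaller than the step to compound 2. The estimate for compound 4 is 4500 nM, with a range from 1500 nM to 14000 nM.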

Compound 4, half-maximal inhibitory concentration: 15400 nM
Estimate against measurement, compound 4: 3.4-fold (0.53 log units) below, outside the stated range (above it).
By their numbers in this assay, from the lowest: compounds 1 and 3 (each within the scatter of the next); then compounds 2 and 4 (each within the scatter of the next).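

In this assay, the step of a 1.2-fold higher number from compound 2 to compound 4 (0.09 log units; within the scatter) shows that the 2,4-dihydroxyphenyl and 2,4-dimethoxyphenyl groups cannot be told apart on the carbon with a double bond to nitrogen, so it makes no visible difference here whether the two oxygens carry hydrogen or a methyl group. The large steps of a 13-fold higher number from compound 3 to compound 4 (1.10 log units; beyond the scatter) and a 22-fold higher number from compound 1 to compound 4 (1.35 log units; beyond the scatter) show that the high numbers are not confined to the methoxy groups of compound 2, and all four compounds now fit a single pattern, with neither phenyl group carrying two oxygen substituents reaching the level of the 2-chloro-4-fluorophenyl or the 1H-indol-3-yl group. Nothing measured here gives a reason for this gap.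

The compounds shown leave open whether one oxygen substituent is enough to produce the high number, as a 4-hydroxyphenyl or a 2-hydroxyphenyl group on the same carbon would show. They also leave open whether the effect belongs to oxygen itself or would extend to other groups at the same two places, such as the amines of a 2,4-diaminophenyl group.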